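This account rests on a few compounds, and the source may have more. Where it says the series, first, only, none or still open, it means among the compounds named here.

Measured compounds:
- compound 1, `O=C(O)CCCC/C=C(\c1cccnc1)c1cccc(F)c1`: 55 nM
- compound 2, `COC(=O)CCCC/C=C(\c1ccccc1)c1cccnc1`: 100 nM
- compound 3, `O=C(O)CCCCCCCCC/C=C(/c1ccccc1)c1cccnc1`: 520 nM

In an assay (Equus caballus) for inhibition of Thromboxane-A synthase (Homo sapiens), using microsomes (a higher number here means a weaker inhibitor, a lower number a stronger inhibitor), compound 1 gives 55 nM, the lowest of the three numbers shown. Compound 2 gives 100 nM, a number that lies within the usual scatter of the value for compound 1, so the two cannot be told apart. Compound 3 gives 520 nM, and this gap is beyond the scatter, so compound 3 is the weaker inhibitor of that pair.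

Compound 4, `O=C(O)CCCC/C=C(/c1ccc(Br)cc1)c1cccnc1`, has not yet been measured. It differs from compound 1 in one place: 4-bromophenyl in place of 3-fluorophenyl on a double-bonded chain carbon bound to an aromatic carbon and a double-bonded chain carbon. Within the data shown here, no step between two measured compounds shows this exchange, and nothing in the numbers above separates a change of the substituent on this ring from the other differences between the compounds. The expectation is therefore a small step from compound 1 to compound 4 that stays within the scatter, or at most a mild rise in the number. The estimated value for compound 4 in this assay is 70 nM, with a likely range from 25 nM to 220 nM, which corresponds to an expected step of a 1.3-fold higher number from compound 1 to compound 4 (0.10 log units; within the scatter).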

Compound 4, half-maximal inhibitory concentration: 82 nM
Compound 4: the middle estimate sits 1.2-fold (0.07 log units) below what was measured; the measured number falls inside the stated range.
By their numbers in this assay, from the lowest: compounds 1, 4 and 2 (each within the scatter of the next); then compound 3.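

In this assay, placing 4-bromophenyl in place of 3-fluorophenyl gives a 1.5-fold higher number from compound 1 to compound 4 (0.17 log units; within the scatter), so the two compounds cannot be told apart. Among these compounds, this is the first step that isolates a single place, and it shows that this exchange on the double-bonded chain carbon leaves the number within the scatter, although the halogen and its place on the ring both differ. No available evidence bears on why the two groups read alike.

The compounds shown leave open whether the identity of the halogen and its place on the ring would each matter if changed alone, and whether an unsubstituted phenyl, a methoxy group or an amine on this ring would also stay within the scatter. They also do not separate the effect of the methyl ester or the longer chain from the other differences in compound 2 and compound 3.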